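Biaryl terminus variation in a fatty acid receptor agonist series

The compounds below may be only part of what the source reports. "The series", "measured", "known", "first", "only" and "open" are said of these compounds alone.

Measured compounds:
Compound 1, `Cc1cc(Cl)ccc1-c1cc(COc2ccc([C@H](CC(=O)O)c3nccn3C)cc2)ccc1C`, 9800 nM
Compound 2, `Cc1c(Cl)cccc1-c1cccc(COc2ccc([C@H](CC(=O)O)c3nccn3C)cc2)c1`, 22000 nM

Both compounds share the same acid-bearing core and differ only in the outer aryl ring. In an assay on CHO cells for agonist activity at Free fatty acid receptor 1 (Homo sapiens), read by luminescence, with a stated time of 20 s, in the presence of a further agent that is not named here (a higher number here means that more compound is needed for the effect, a lower number that less compound is needed), compound 2 gives the higher of the two numbers; compound 1 sits lower, and the gap between the two lies beyond the usual scatter.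

Compound 3, `Cc1cccc(C)c1-c1cccc(COc2ccc([C@H](CC(=O)O)c3nccn3C)cc2)c1`, has not yet been measured. It differs from compound 2 in one place: 2,6-dimethylphenyl in place of 3-chloro-2-methylphenyl on an aromatic carbon. The change swaps a chlorine-bearing ring for one carrying two methyl groups, keeping the same atom count and no change in donors, acceptors or charge.

Going by the values given here, with only two measured points and no single-change pair among them, there is no basis for a directional call. The step from compound 2 to compound 3 is therefore expected to stay within the scatter, a 1.1-fold lower number from compound 2 to compound 3 (0.04 log units; within the scatter). Compound 3 is estimated at 20000 nM, in the range 8000 nM to 50000 nM.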

Compound 3, half-maximal effective concentration: 29000 nM
Estimate against measurement, compound 3: 1.5-fold (0.16 log units) below; the range from low to high includes it.
By their numbers in this assay, from the lowest: compound 1; then compounds 2 and 3 (each within the scatter of the next).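

In this assay, 2,6-dimethylphenyl in place of 3-chloro-2-methylphenyl on an aromatic carbon gives a 1.3-fold higher number from compound 2 to compound 3 (0.12 log units; within the scatter), the only single-change step that can be read among the compounds shown. At this position, then, the two outer rings cannot be told apart in this assay, even though one carries chlorine and the other an all-carbon substitution with the same heavy-atom count. No measurement is available that bears on the reason for this result.

Going by these compounds, whether an amine or a methoxy group on this outer ring would give a step beyond the scatter remains open. Compound 1 has no single-change link to compound 2 or compound 3, so its value cannot yet be tied to any one feature of its structure.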